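Aryl for cyclohexyl on the lactam nitrogen: working notes

This account rests on a few compounds, and the source may have more. Where it says the series, first, only, none or still open, it means among the compounds named here.

Compound 1 `COc1ncc(-c2ccc3c(c2)N(c2ccc(C)cc2)C(=O)CO3)cc1NS(=O)(=O)c1ccc(F)cc1` carries a 4-methylphenyl on the amide-type nitrogen in a ring; in a functional assay on HCT-116 cells (Homo sapiens) for antiproliferative activity, read by MTT assay, with a stated time of 72 h (a higher number here means a weaker inhibitor, a lower number a stronger inhibitor), compound 1 gives 22700 nM. Compound 2 `COc1ncc(-c2ccc3c(c2)N(C2CCCCC2)C(=O)CO3)cc1NS(=O)(=O)c1ccc(F)cc1` has cyclohexyl in the same place. In this assay compound 2 reaches only the limit > 40000 nM, which is a limit of the assay and not a number. The change between them, (4-methylphenyl in place of cyclohexyl on an amide-type nitrogen in a ring), made an at least 1.7-fold lower number from compound 2 to compound 1 (0.24 log units; that floor lies within the scatter). Compound 3 `O=C1COc2ccc(-c3cnc4ccccc4c3)cc2N1C1CCCCC1` is built on another core; the difference between the two cores is not broken down here. In this assay compound 3 sits at the limit > 40000 nM, again a limit rather than a number. Two of the three known values are limits (the limit of > 40000 nM in this assay, at which 2 of the 3 values shown sit). Compound 4 `Cc1ccc(N2C(=O)COc3ccc(-c4cnc5ccccc5c4)cc32)cc1` repeats the same change on the core of compound 3: 4-methylphenyl in place of cyclohexyl on an amide-type nitrogen in a ring. The place is described in the same words for both pairs, so it is the same change. The step expected from compound 3 to compound 4 is an at least 1.1-fold lower number from compound 3 to compound 4 (0.05 log units; that floor lies within the scatter), resting on the measured step of an at least 1.7-fold lower number from compound 2 to compound 1 (0.24 log units; that floor lies within the scatter), whose floor lies within the scatter. Compound 4 is therefore expected at 35000 nM, between 15000 nM and 80000 nM.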

Compound 4, half-maximal inhibitory concentration: > 40000 nM
Compound 4: no number, only a limit (the forecaster's own chance of this, stated with the estimate: 55%); middle value at least 1.1-fold (0.05 log units) from the limit.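

No step can be read between compound 3 and compound 4, since both stand at a limit and not at a number: the limit of > 40000 nM in this assay, at which 3 of the 4 values shown sit.

The compounds shown leave open whether 4-methylphenyl in place of cyclohexyl on an amide-type nitrogen in a ring changes the antiproliferative read-out at all on the core of compound 3.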